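This account rests on a few compounds, and the source may have more. Where it says the series, first, only, none or still open, it means among the compounds named here.

Compound 1 `CCCCNc1nc(N)nc2c1CN(S(C)(=O)=O)CC2` has the higher of the two numbers recorded in an assay on HEK293 cells for agonist activity at Toll-like receptor 8 (Homo sapiens), read by a luciferase reporter, with a stated time of 6 h; on this read-out lower numbers stand for an effect already at smaller amounts and higher numbers for an effect only at larger amounts of compound: compound 1 gives 9.9 uM, while compound 2 `CCCCNc1nc(N)nc2c1CN(Cc1c[nH]c3ccccc13)CC2` gives 0.22 uM, a gap beyond the usual scatter. Compound 3 `CCCCNc1nc(N)nc2c1CN(C(=O)c1csnn1)CC2` has not yet been measured. It differs from compound 1 in one place ((1,2,3-thiadiazol-4-yl)carbonyl in place of methylsulfonyl on an amine nitrogen in a ring). Going by the values given here, with no comparable step on record, the expectation rests on the aromatic ring entering the same position where compound 2 also carries one; a moderate move toward a lower number is expected, a 3.3-fold lower number from compound 1 to compound 3 (0.52 log units; beyond the scatter). Compound 3 is therefore estimated at 3 uM in this assay, within a range from 0.5 uM to 15 uM.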

Compound 3, minimum effective concentration: 0.1 uM
For compound 3 the middle estimate is 30-fold (1.48 log units) above the measured one; the whole stated range lies above it.
By their numbers in this assay, from the lowest: compound 3; then compound 2; then compound 1.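

On the amine nitrogen in a ring, the choice of group has a large effect in this assay: replacing methylsulfonyl with (1,2,3-thiadiazol-4-yl)carbonyl gives a 99-fold lower number from compound 1 to compound 3 (2.00 log units; beyond the scatter) while the shared core stays the same. This position therefore accepts a carbonyl group carrying a five-membered aromatic ring, and that change brings a large gain. No measurement here explains the gain. The compounds shown leave open whether the carbonyl or the aromatic ring matters more. An acetyl group, which has the carbonyl without the ring, would help separate the two.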